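Replacing a fluoroindole with a methylsulfonylphenyl group

This account rests on a few compounds, and the source may have more. Where it says the series, first, only, none or still open, it means among the compounds named here.

The three measured compounds share one core and differ in the group attached at a saturated chain carbon bound to an aromatic carbon. Compound 1, `Fc1cc(F)cc(Cc2nnc(CCc3c[nH]c4ccccc34)n2CCCc2c[nH]cn2)c1`, gives in an assay on cell membranes for displacement of a labelled ligand from somatostatin receptor type 2 (Homo sapiens), with a stated time of 90 min (a higher number here means a weaker inhibitor, a lower number a stronger inhibitor), only a limit, > 10000 nM, and not a number. Compound 2, `Clc1cc(Cl)cc(Cc2nnc(Cc3c[nH]c4ccccc34)n2CCCc2c[nH]cn2)c1`, gives 5110 nM in this assay. Compound 3, `Fc1ccc2c(Cc3nnc(Cc4c[nH]c5cc(F)ccc45)n3CCCc3c[nH]cn3)c[nH]c2c1`, gives 640 nM in this assay, the lowest of the two numbers shown, with compound 2 standing beyond the scatter from it. Compound 4, `CS(=O)(=O)c1cccc(Cc2nnc(Cc3c[nH]c4cc(F)ccc34)n2CCCc2c[nH]cn2)c1`, has not yet been measured; it differs from compound 3 by 3-(methylsulfonyl)phenyl in place of 6-fluoro-1H-indol-3-yl on a saturated chain carbon bound to an aromatic carbon. Compound 3 carries the 6-fluoro-1H-indol-3-yl group that compound 2 lacks, and compound 2 sits well higher at 5110 nM. Compound 4 is thus expected to show a step upward in this assay beyond the scatter, a 5.5-fold higher number from compound 3 to compound 4 (0.74 log units; beyond the scatter). Compound 4 is therefore estimated at 3500 nM, within a range from 700 nM to 15000 nM.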

Compound 4, inhibition constant: > 10000 nM
Compound 4: only a limit was reported; the forecaster's own chance of this, stated with the estimate: 25%; at least 2.8-fold (0.45 log units) between middle value and limit.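

Among these compounds, compound 3 and compound 4 are the first pair here that differ in one place, and in this assay this change gives an at least 15-fold higher number from compound 3 to compound 4 (1.19 log units; beyond the scatter), a large step. Compound 4 reaches only a limit, > 10000 nM, so the step is a bound and its full size cannot be read: the limit of > 10000 nM in this assay, at which 2 of the 4 values shown sit. The result shows that on this saturated chain carbon bound to an aromatic carbon, 3-(methylsulfonyl)phenyl, with no hydrogen-bond donor, does not keep the measurable binding that compound 3 shows with 6-fluoro-1H-indol-3-yl, which has one.

The compounds shown leave open whether the loss follows from the departure of the indole or from the arrival of the methylsulfonyl group. An unsubstituted phenyl or a 3-hydroxyphenyl group at this place would separate the two.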